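The compounds below may be only part of what the source reports. "The series", "measured", "known", "first", "only" and "open" are said of these compounds alone.

Series notes. Three compounds have been run in a functional assay with Homo sapiens as the target, read by hemolysis; a lower number here means a stronger inhibitor, a higher number a weaker inhibitor. Compound 1 `CC1(C)C2CC[C@@H](Cc3ccc(C(=O)O)cc3)C[C@@]2(C)CC[C@@H]1O` gives 610000 nM, compound 2 `CC1(C)C2CCC[C@H](/C=C/c3ccccc3C(=O)O)[C@@]2(C)CC[C@@H]1O` gives 633000 nM, and compound 3 `COc1ccc(CO[C@H]2CC[C@]3(C)C[C@H](Cc4cccc(C(=O)O)c4)CCC3C2(C)C)cc1` gives 488000 nM. In this assay compound 3 stands alongside compound 1 and compound 2: its value and theirs fall within the usual scatter of one another, so the three cannot be ranked on these numbers. Within the data shown here, no two measured compounds differ in a single place, so no measured step exists in the set. Compound 4 `CC1(C)C2CC[C@@H](Cc3cccc(C(=O)O)c3)C[C@@]2(C)CC[C@@H]1O` is the next point; it differs from compound 3 by hydrogen in place of 4-methoxybenzyl on an oxygen on a saturated carbon. Compound 4 carries the same hydroxy as compound 1, and the expectation of no real shift rests on compound 1 giving 610000 nM while compound 3 gives 488000 nM. In this assay the expected step is a 1.1-fold higher number from compound 3 to compound 4 (0.06 log units; within the scatter), which is none beyond the scatter. Compound 4 is expected to give 560000 nM in this assay, within a range from 300000 nM to 1000000 nM.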

Compound 4, half-maximal inhibitory concentration: 601000 nM
Beside the measured number, compound 4's estimate is 1.1-fold (0.03 log units) below it; the measured number falls inside the stated range.
By their numbers in this assay, from the lowest: compounds 3, 4, 1 and 2 (each within the scatter of the next).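

In this assay, among these compounds, hydrogen in place of 4-methoxybenzyl on an oxygen on a saturated carbon gives a 1.2-fold higher number from compound 3 to compound 4 (0.09 log units; within the scatter), the only step between compounds that differ in one place. At this position, the hydroxy and the (4-methoxybenzyl)oxy group therefore cannot be told apart on these numbers. A substituent of 9 heavy atoms, including one six-membered aromatic ring, enters on this oxygen with no shift beyond the scatter. No measured property bears on this result, and it stands without an explanation.

Still open, from the compounds shown here alone, is whether an amine in place of the hydroxy, or a small acetyl group on that oxygen, would move the number beyond the scatter. Also open, going by these compounds, is whether a tetrazole or a primary amide in place of the carboxylic acid would do so.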